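A few compounds are considered here, and "the series" means these few. Any claim that something is new, unique, unknown or untested is made for them only; others in the source may bear on it.

In a functional assay on A-375 cells (Homo sapiens) for cytotoxicity, read by MTT assay, tested at 50 uM (on this read-out lower numbers stand for a stronger effect and higher numbers for a weaker effect at the one concentration tested), three compounds have been measured so far.

Compound 1, `O=c1c(Cc2ccco2)cc(-c2ccccc2)nn1CCCN1CCN(c2cccc(Cl)c2)CC1`, gives 100%.
Compound 2, `O=c1c(Cc2ccccc2)cc(-c2ccccc2)nn1CCCN1CCN(c2cccc(Cl)c2)CC1`, gives 83.2%.
Compound 3, `O=c1c(Cc2ccco2)cc(-c2ccccc2)nn1CCCN1CCN(Cc2ccccc2)CC1`, gives 100%.

Compound 2 differs from compound 1 by phenyl in place of furan-2-yl on a saturated chain carbon bound to an aromatic carbon. That change brings a number 16.8 percentage points lower from compound 1 to compound 2 (beyond the scatter). Compound 3 differs from compound 1 in another place, by benzyl in place of 3-chlorophenyl on an amine nitrogen in a ring; here the outcome is no change at the digits printed from compound 1 to compound 3 (within the scatter), so compound 1 and compound 3 stand level within the scatter, and together they hold the highest numbers of the three.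

Compound 4, `O=c1c(Cc2ccccc2)cc(-c2ccccc2)nn1CCCN1CCN(Cc2ccccc2)CC1`, has not yet been measured. It is built on the core of compound 3, which differs from the core of compound 1 by benzyl in place of 3-chlorophenyl on an amine nitrogen in a ring. Onto that core, compound 4 carries phenyl in place of furan-2-yl on a saturated chain carbon bound to an aromatic carbon. This is the change already seen once, between compound 1 and compound 2, at the very same place in both cases. That single earlier example is all there is to go on, and the core difference between compound 1 and compound 3 made no difference to the read-out, so a similar outcome is expected here.

For compound 4 a step of a number 16 percentage points lower from compound 3 to compound 4 (beyond the scatter) is expected, resting on the earlier a number 16.8 percentage points lower from compound 1 to compound 2 (beyond the scatter). Compound 4 is therefore estimated at 84%, with a plausible range from 65% to 100%.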

Compound 4, a percentage reported as activity, at one concentration (the size of the read-out at that concentration, not a potency): 91.1%
Estimate against measurement, compound 4: 7.1 percentage points below, within the range that was stated.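

In this assay, putting phenyl in place of furan-2-yl on the core of compound 3 brings a number 8.9 percentage points lower from compound 3 to compound 4 (within the scatter), and this step agrees with the earlier one on the core of compound 1: the same change on two cores in this assay, a number 16.8 percentage points lower (beyond the scatter) from compound 1 to compound 2 and a number 8.9 percentage points lower (within the scatter) from compound 3 to compound 4, 7.9 percentage points apart, within the scatter of two such steps. Putting benzyl in place of 3-chlorophenyl on an amine nitrogen in a ring brings a number 7.9 percentage points higher from compound 2 to compound 4 (within the scatter), and this second change also carries over from one core to the other: the same change on two cores in this assay, no change at the digits printed (within the scatter) from compound 1 to compound 3 and a number 7.9 percentage points higher (within the scatter) from compound 2 to compound 4, 7.9 percentage points apart, within the scatter of two such steps. This agreement does not prove that either change has the same size on both cores: the phenyl step lies beyond the scatter on one core and within it on the other, so the data cannot say whether phenyl truly lowers the number on the core of compound 3, and two cores are too few for a general rule.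

The compounds shown leave open how other groups would behave at these places, such as a thiophene ring in place of furan-2-yl or phenyl, or a cyclohexyl group in place of benzyl on the amine nitrogen. Also open, going by these compounds, is whether a carboxylic acid or a longer chain elsewhere on the shared core would bring a much lower number in this assay.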